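The source may report more compounds than this note shows. Statements on the series, on what has been measured and on what is new or still open speak of the compounds shown alone.

Compound 1 `CC(C)C(NC(=O)c1ccc([N+](=O)[O-])o1)c1ccccc1` gives 22000 nM in an ADME assay on Vero cells (Chlorocebus sabaeus) for cytotoxicity, read by MTT assay, with a stated time of 48 h; a lower number here means that less compound is tolerated, a higher number that more compound is tolerated.
Compound 2 `O=C(NC(c1ccccc1)C1CC1)c1ccc([N+](=O)[O-])o1` gives 22000 nM in this assay.
Compound 3 `CC(C)(NC(=O)c1ccc([N+](=O)[O-])o1)c1ccc(Cl)cc1` gives 81000 nM in this assay.

Compound 3 stands highest of the three, and its gap to each of the others lies beyond the scatter, so it is the best tolerated of the set. Compound 1 and compound 2 sit within the scatter of each other: the step of no change at the digits printed from compound 1 to compound 2 (within the scatter) shows no change. Compound 4 `CC(C)(NC(=O)c1ccc([N+](=O)[O-])o1)c1ccc(-c2ccc(Cl)cc2)cc1` differs from compound 3 by 4-chlorophenyl in place of chloro on an aromatic carbon. The one measured step alters the saturated carbon next to the amide nitrogen, not a group on the aromatic ring, so no measured step bears on this change and the direction rests on no shown number. A moderate drop is expected, a 2.0-fold lower number from compound 3 to compound 4 (0.31 log units; beyond the scatter), with compound 4 estimated at 40000 nM and a range from 15000 nM to 100000 nM.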

Compound 4, half-maximal cytotoxic concentration: > 140000 nM
Compound 4 was reported as a limit; the forecaster's own chance of this, stated with the estimate: 10%; middle value at least 3.5-fold (0.54 log units) away from the limit.
By their numbers in this assay, from the lowest: compounds 1 and 2 (each within the scatter of the next); then compound 3. At a limit, above all of these: compound 4.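

Putting 4-chlorophenyl in place of chloro on an aromatic carbon gives an at least 1.7-fold higher number from compound 3 to compound 4 (0.23 log units; that floor lies within the scatter) in this assay. Among the compounds shown here, this is the first measured change on that ring, and adding a second six-membered aromatic ring brings no fall in the number, although the guaranteed rise alone stays within the usual scatter. Compound 4 is reported only as a limit: the limit of > 140000 nM in this assay, at which 1 of the 4 values shown sits.

As far as these compounds go, the true size of this step stays open. So does whether an amine or a carboxylic acid on this aromatic carbon would keep the number as high.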